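A Chloro Step Repeated on a Weaker Core

The source may hold more compounds than are shown below. What is called first, only, known or untested is meant among the compounds shown, and "the series" means these compounds.

Compound 1, `Nc1nc2cc(Cl)c(Cl)cc2n1Cc1ccc(Cl)cc1`: 32000 nM
Compound 2, `Nc1nc2cc(Cl)c(Cl)cc2n1Cc1ccc(Cl)c(Cl)c1`: 30000 nM
Compound 3, `Clc1cc2nc(Br)n(Cc3ccccc3)c2cc1Cl`: > 100000 nM, a limit of the assay

All three were tested in a functional assay on CEM-SS cells (Homo sapiens) for cytotoxicity; on this read-out lower numbers stand for stronger inhibition and higher numbers for weaker inhibition. Compound 1 and compound 2 share one core, and compound 2 differs from compound 1 only by chloro in place of hydrogen on an aromatic carbon. The step of a 1.1-fold lower number from compound 1 to compound 2 (0.03 log units; within the scatter) shows that this change left the read-out essentially where it was. Compound 3 rests on a different core; how the two cores differ is not broken down here. In this assay compound 3 gives > 100000 nM, which is a limit of the assay and not a number.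

Compound 4, `Clc1cc2nc(Br)n(Cc3ccccc3Cl)c2cc1Cl`, is still to be measured. It differs from compound 3 by chloro in place of hydrogen on an aromatic carbon. This is the same kind of change as that from compound 1 to compound 2, but the surroundings of the place differ: in compound 2 the chloro enters ortho to a chloro group and meta to a large group, whereas in compound 4 it enters ortho to a large group.

The step of a number no higher from compound 3 to compound 4 (the limit leaves the size open) is expected to be small, since the step of a 1.1-fold lower number from compound 1 to compound 2 (0.03 log units; within the scatter) was within the scatter. Compound 4 is therefore expected to give about 100000 nM in this assay, most likely again as a limit, due to the limit of > 100000 nM in this assay, at which 1 of the 3 values shown sits, where compound 3 sits. The range expected for compound 4 runs from 30000 nM to 300000 nM.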

Compound 4, half-maximal inhibitory concentration: 74000 nM
Compound 4: the middle estimate sits 1.4-fold (0.13 log units) above what was measured; the measured number falls inside the stated range.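

In this assay compound 3 gives > 100000 nM, which is a limit of the assay and not a number. Chloro in place of hydrogen on an aromatic carbon, here ortho to a large group, can therefore be read only as a floor, an at least 1.3-fold lower number from compound 3 to compound 4 (0.13 log units; that floor lies within the scatter), and that floor does not by itself establish a real change on this core. Set beside the earlier step, the result gives no sign that the two cores respond differently to this change, but it does not show that the change carries over from one core to the other with the same size, and the true size of the new step remains unknown: the same change on two cores in this assay, a 1.1-fold lower number (0.03 log units; within the scatter) from compound 1 to compound 2 and an at least 1.3-fold lower number (0.13 log units; that floor lies within the scatter) from compound 3 to compound 4; the limit leaves it open whether they differ.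

The compounds shown leave open how far the read-out would move on the core of compound 3 if the chloro stood at another place on the same ring, and whether the step would keep its size there. They also leave open what other groups would do at the place taken by the chloro in compound 4, for instance a methoxy group, a carboxylic acid or a longer chain.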